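A few compounds are considered here, and "the series" means these few. Any claim that something is new, unique, unknown or untested is made for them only; others in the source may bear on it.

Measured so far:

Compound 1 `COc1cc(/C=C/C(=O)/C=C/c2cccs2)ccc1OCc1cn(CCCCCOc2cc(=O)oc3ccccc23)nn1`: 30%
Compound 2 `COc1ccc(/C=C/C(=O)/C=C/c2ccc(OCc3cn(CCCCCOc4cc(=O)oc5ccccc45)nn3)c(OC)c2)cc1`: 30%
Compound 3 `COc1cc(/C=C/C(=O)/C=C/c2cccs2)ccc1OCc1cn(CCCCOc2cc(=O)oc3ccccc23)nn1`: 40%

These three compounds were tested in a functional assay on COLO 205 cells (Homo sapiens) for inhibition, read by sulforhodamine B assay, with a stated time of 48 h, tested at 50 uM; on this read-out higher numbers stand for more inhibition of growth at the one concentration tested and lower numbers for less inhibition of growth. In this assay compound 1 gives 30% and compound 2 gives 30%, so the two values sit within the usual scatter of each other. Compound 3 gives 40% in this assay, and its value is also within the scatter of both compound 1 and compound 2, so no order among the three can be read from these numbers.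

Compound 1 and compound 2 differ in one place: 4-methoxyphenyl in place of thiophen-2-yl on a double-bonded chain carbon bound to a double-bonded chain carbon. That step gives no change at the digits printed from compound 1 to compound 2 (within the scatter), a step of no size at all within the scatter.

Compound 3 differs from compound 1 by more than one place; the difference between the two cores is not broken down here.

Compound 4 `COc1ccc(/C=C/C(=O)/C=C/c2ccc(OCc3cn(CCCCOc4cc(=O)oc5ccccc45)nn3)c(OC)c2)cc1` has not yet been measured. It stands to compound 3 as compound 2 stands to compound 1: 4-methoxyphenyl in place of thiophen-2-yl on a double-bonded chain carbon bound to a double-bonded chain carbon. The place line is the same word for word in both cases, so this is the same change. Because no change at the digits printed from compound 1 to compound 2 (within the scatter) showed no movement from the same change on the core of compound 1, the step from compound 3 to compound 4 is expected to be a number 2 percentage points lower from compound 3 to compound 4 (within the scatter), again of no size within the scatter. Compound 4 is therefore estimated to give 38% in this assay, with a range expected from 22% to 52%.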

Compound 4, percent growth inhibition at one concentration: 49%
Compound 4: middle estimate off by 11 percentage points, on the low side; the range from low to high includes it.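

Replacing thiophen-2-yl with 4-methoxyphenyl on a double-bonded chain carbon bound to a double-bonded chain carbon has now been read on two cores in this assay, and on the second core the result is a number 9 percentage points higher from compound 3 to compound 4 (within the scatter). Set side by side, the two readings do not differ by more than repeated measurements of this kind normally would: the same change on two cores in this assay, no change at the digits printed (within the scatter) from compound 1 to compound 2 and a number 9 percentage points higher (within the scatter) from compound 3 to compound 4, 9 percentage points apart, within the scatter of two such steps. This shows that, for these two pairs, the swap behaves the same on both cores as far as this read-out can tell, but it does not prove that the swap has no effect or that the two cores truly respond alike, and two pairs cannot establish a rule for the wider series.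

The compounds shown leave open whether any group at this place would produce a step beyond the scatter, since only thiophen-2-yl and 4-methoxyphenyl appear there. As far as these compounds go, it also remains open how an amine or a carboxylic acid on that aromatic ring would read in this assay, and whether such a change would carry from one core to the other in the same way.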